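This account rests on a few compounds, and the source may have more. Where it says the series, first, only, none or still open, it means among the compounds named here.

Measured so far in an assay on CHO cells for displacement of a labelled ligand from adenosine receptor A1 (Homo sapiens), tested at 10 uM; a lower number here means less inhibition, a higher number more inhibition at the concentration tested (going by the name of the read-out):
compound 1 `O=C(NCc1ccccc1)Nc1nn(-c2ccccc2)c(=O)c2ccccc12` gives 20%
compound 2 `O=C(Nc1nn(-c2ccccc2)c(=O)c2ccccc12)c1ccco1` gives 23%
compound 3 `CC(=O)N(C(C)=O)c1nn(-c2ccccc2)c(=O)c2ccccc12` gives 47%

Compound 2 stands at the middle of the three numbers; its nearest neighbour is compound 1, at a gap that lies within the scatter, while compound 3 stands beyond the scatter above it. The next entry is compound 4 `O=C(Nc1nn(-c2ccccc2)c(=O)c2ccccc12)c1ccc(Cl)cc1`, not yet measured. It differs from compound 2 in one place: 4-chlorophenyl in place of furan-2-yl on a carbonyl carbon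

Of the two measured steps, the one that touches the same place is a number 3 percentage points higher from compound 1 to compound 2 (within the scatter), an exchange of the group on the carbonyl carbon that left the number essentially where it was. The other step, a number 24 percentage points higher from compound 2 to compound 3 (beyond the scatter), alters the group on the aromatic carbon and is of a different kind, so it says little about swapping one ring for another on the carbonyl carbon. Among the measured compounds shown here, no measured pair sets a furan-2-yl against a 4-chlorophenyl. The expectation is therefore a step of about a number 2 percentage points higher from compound 2 to compound 4 (within the scatter), that is, nothing beyond the scatter. Compound 4 is estimated at 25%, within a range from 8% to 45%.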

Compound 4, a percentage reported as inhibition, at one concentration (the size of the read-out at that concentration, not a potency): 26%
For compound 4 the middle estimate is 1 percentage points below the measured one, and the stated range covers the measured number.
By their numbers in this assay, from the lowest: compounds 1, 2 and 4 (each within the scatter of the next); then compound 3.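

In this assay, the group on the carbonyl carbon has now been varied across benzylamino, furan-2-yl and 4-chlorophenyl, and the number barely responds: the ring exchange gives a number 3 percentage points higher from compound 2 to compound 4 (within the scatter), and 4-chlorophenyl in place of benzylamino gives a number 6 percentage points higher from compound 1 to compound 4 (within the scatter). A five-membered aromatic ring with a hetero atom and a six-membered aromatic ring of carbon only thus cannot be told apart at this position, and the chlorine-bearing ring adds no measurable gain over either earlier group. Nothing available explains this flat response.

Still open, as far as these compounds go, is whether a different type of group on this carbonyl carbon, such as a piperidine amine, a carboxylic acid or a longer alkyl chain, would move the number beyond the scatter. Also open, from the compounds shown here alone, is whether any such group could reach the level of the diacetylamino compound 3, at 47%.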